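Swapping a Pyridine for a Pyrazine on the Shared Core

The compounds below may be only part of what the source reports. "The series", "measured", "known", "first", "only" and "open" are said of these compounds alone.

Measured in a functional assay on PANC-1 cells (Homo sapiens), read by microscopy, crystal violet staining and transwell migration, with a stated time of 18 h, in the presence of a further agent that is not named here; on this read-out higher numbers stand for weaker inhibition and lower numbers for stronger inhibition:
- compound 1 `CCOc1ccc(-c2nc(CC)nn2-c2cccc(C(=O)NCCCCc3ccccc3)c2)cc1`: 16800 nM
- compound 2 `CCc1nc(-c2ccc(OC)cn2)n(-c2cccc(C(=O)NCCCCc3ccccc3)c2)n1`: 120 nM

Compound 2, at 120 nM, holds the lower of the two numbers, and a lower number means stronger inhibition. Compound 3 `CCc1nc(-c2cnc(OC)cn2)n(-c2cccc(C(=O)NCCCCc3ccccc3)c2)n1` carries 5-methoxypyrazin-2-yl in place of 5-methoxypyridin-2-yl on an aromatic carbon. For the measured compounds named here, the only measured step, a 140-fold lower number from compound 1 to compound 2 (2.15 log units; beyond the scatter), is large and beyond the scatter, but it involves a different swap, from 4-ethoxyphenyl. Going by the values given here, no measured step tests the present swap, so no step beyond the scatter is expected in this assay. The estimated step is a 1.3-fold higher number from compound 2 to compound 3 (0.12 log units; within the scatter). Compound 3 is expected at 160 nM, within a range of 30 nM to 900 nM.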

Compound 3, half-maximal inhibitory concentration: 310 nM
Compound 3: the middle estimate sits 1.9-fold (0.29 log units) below what was measured; measured number inside the range.
By their numbers in this assay, from the lowest: compound 2; then compound 3; then compound 1.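

Exchanging 5-methoxypyridin-2-yl for 5-methoxypyrazin-2-yl, which puts one more nitrogen into the six-membered ring, gives a 2.6-fold higher number from compound 2 to compound 3 (0.41 log units; beyond the scatter) and so weakens inhibition modestly. This position therefore responds to a change of a single ring atom. Most of the advantage over 4-ethoxyphenyl remains, as a 54-fold lower number from compound 1 to compound 3 (1.73 log units; beyond the scatter) shows on this read-out. No measured evidence is available to explain these steps. Still open, going by these compounds, is whether an amine in place of the methoxy group on 5-methoxypyrazin-2-yl would preserve or weaken this inhibition.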